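A few compounds are considered here, and "the series" means these few. Any claim that something is new, unique, unknown or untested is made for them only; others in the source may bear on it.

Compound 1 `Cc1c(OCCCCOc2ccccc2C(=O)O)ccc(C(=O)CC(C)C)c1O` gives the lowest of the two numbers in an assay on HEK293 cells for positive allosteric modulation of metabotropic glutamate receptor 2 (Rattus norvegicus), read by thallium flux, with a stated time of 2.5 min (a higher number here means that more compound is needed for the effect, a lower number that less compound is needed), at 415 nM; compound 2 `Cc1c(OCCCCOc2ccccc2C(=O)O)ccc(C(=O)CC(C)C)c1C` gives 976 nM, a step of a 2.4-fold higher number from compound 1 to compound 2 (0.37 log units; beyond the scatter). Compound 3 `Cc1ccc(C(=O)O)cc1OCCCCOc1ccc(C(=O)CC(C)C)c(O)c1C` differs from compound 1 at the chain end: 5-carboxy-2-methylphenyl in place of 2-carboxyphenyl on an oxygen on a saturated carbon. Within the data shown here, the one measured step, methyl in place of hydroxy on an aromatic carbon, changes a different part of the shared core and does not bear on this change; no measured pair varies the carboxyphenyl group. Compound 3 is therefore expected to stay within the scatter of compound 1, as a 1.2-fold higher number from compound 1 to compound 3 (0.08 log units; within the scatter). The estimate for compound 3 is 500 nM, range 150 nM to 1700 nM.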

Compound 3, half-maximal effective concentration: 454 nM
Compound 3: the middle estimate sits 1.1-fold (0.04 log units) above what was measured, within the range that was stated.
By their numbers in this assay, from the lowest: compounds 1 and 3 (each within the scatter of the next); then compound 2.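

With 5-carboxy-2-methylphenyl in place of 2-carboxyphenyl on an oxygen on a saturated carbon, this assay shows a 1.1-fold higher number from compound 1 to compound 3 (0.04 log units; within the scatter). This end of the chain therefore accepts this one replacement of the carboxyphenyl group, with an added methyl and a different carboxy placement, without a step beyond the scatter. No available evidence explains this result.

Still open, going by these compounds, is what the methyl and the carboxy placement each contribute on their own. Also open, on these data alone, is whether a tetrazole or a primary amide can stand in for the carboxylic acid on this ring.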